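The source may hold more compounds than are shown below. What is called first, only, known or untested is meant among the compounds shown, and "the series" means these compounds.

Among the compounds with values here, in a functional assay on MCF7 cells (Homo sapiens) for antiproliferative activity, with a stated time of 5 days (on this read-out higher numbers stand for weaker inhibition and lower numbers for stronger inhibition), compound 1 `CCCCc1ccc2[nH]c(-c3ccc(OC)cc3)c(/C=N/NC(=O)c3ccccc3)c2c1` gives 130 nM and compound 2 `CCCCc1ccc2[nH]c(-c3ccc(OC)cc3)c(/C=N/NC(=O)c3ccc(Cl)cc3)c2c1` gives 220 nM, so compound 2 stands within the scatter of the only other measured number. Compound 3 `CCCCc1ccc2[nH]c(-c3ccc(OC)cc3)c(/C=N/NC(=O)c3ccc(OC)cc3)c2c1` differs from compound 2 by methoxy in place of chloro on an aromatic carbon, para to a large group. Within the data shown here, the one measured step at this place, a 1.7-fold higher number from compound 1 to compound 2 (0.23 log units; within the scatter), is chloro in place of hydrogen. It therefore gives no reason to expect a shift beyond the scatter in this assay. The expected change is a 1.3-fold lower number from compound 2 to compound 3 (0.11 log units; within the scatter). Compound 3 is estimated at 170 nM, with an expected range of 70 nM to 400 nM.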

Compound 3, half-maximal inhibitory concentration: 226 nM
The estimate for compound 3 lay 1.3-fold (0.12 log units) below the measured number, within the range that was stated.
By their numbers in this assay, from the lowest: compounds 1, 2 and 3 (each within the scatter of the next).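

In this assay the position shows a 1.0-fold higher number from compound 2 to compound 3 (0.01 log units; within the scatter) with methoxy in place of chloro, and a 1.7-fold higher number from compound 1 to compound 3 (0.24 log units; within the scatter) with methoxy in place of hydrogen. Adding a hydrogen-bond acceptor at this place, on the aromatic carbon para to a large group, therefore gives no step beyond the scatter, and hydrogen, chloro and methoxy are not separated here. No available evidence bears on this result. Still open, going by these compounds, is how an amine or a carboxylic acid at this position would read out. On these data alone, a longer chain in place of the one on the shared core also remains open.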